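Phenyl in place of cyclopropyl on the pyridinyl cyanoguanidine

The compounds below may be only part of what the source reports. "The series", "measured", "known", "first", "only" and "open" are said of these compounds alone.

Three compounds sharing the core of compound 1 `N#CN/C(=N\C1CC1)Nc1cccnc1` have been tested in a functional assay on the whole organism (blood, strain Wistar-Okamoto) with Rattus norvegicus as the target, with a stated time of 5 days; on this read-out higher numbers stand for an effect only at larger amounts of compound and lower numbers for an effect already at smaller amounts. Compound 1 gives 20 mg/kg, the second highest of the three numbers. Compound 2 `CCC(CC)(CC)/N=C(\NC#N)Nc1cccnc1` gives 1 mg/kg, a lower number than compound 1 by a margin beyond the scatter, while compound 3 `CC(C)(C)CC(C)(C)/N=C(\NC#N)Nc1cccnc1` gives 50 mg/kg, a higher number than compound 1, also beyond the scatter. The untested compound 4 `N#CN/C(=N\c1ccccc1)Nc1cccnc1` differs from compound 1 in one place: phenyl in place of cyclopropyl on a double-bonded nitrogen. Among the measured compounds shown here, no pair of measured compounds shows this exchange, so its effect cannot be read from the data at hand. On this basis, the step of no change at the digits printed from compound 1 to compound 4 (within the scatter) is expected to stay within the scatter. Compound 4 is estimated at 20 mg/kg, with a range from 5 mg/kg to 80 mg/kg.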

Compound 4, minimum effective dose: 5 mg/kg
Beside the measured number, compound 4's estimate is 4.0-fold (0.60 log units) above it; the measured number falls inside the stated range.
By their numbers in this assay, from the lowest: compound 2; then compound 4; then compound 1; then compound 3.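

In this assay, among the compounds shown here, phenyl in place of cyclopropyl on a double-bonded nitrogen gives a 4.0-fold lower number from compound 1 to compound 4 (0.60 log units; beyond the scatter) and so provides the one readable change at this position. The step is modest, but it shows that a six-membered aromatic ring of carbon only is compatible with an effect at smaller amounts than the three-membered ring in compound 1. No measurement at hand bears on the reason for this step. On these data alone, it remains open whether ring size or aromatic character accounts for the step, and a cyclohexyl group would help separate the two. As far as these compounds go, the effect of a methoxy group on the phenyl ring also remains open.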